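Solubility notes: compound 1 to compound 4

This account rests on a few compounds, and the source may have more. Where it says the series, first, only, none or still open, it means among the compounds named here.

Compound 1 `CCOC(=O)c1c(-c2ccccc2C)[nH]c2cc(OC)ccc2c1=O` stands in a physicochemical assay for solubility, in phosphate buffer, at pH 7.4 (on this read-out lower numbers stand for lower solubility and higher numbers for higher solubility), only as a limit: compound 1 gives > 100000 nM. Compound 2 `CCOC(=O)c1c(-c2cccc(OC)c2)[nH]c2cccc(OC)c2c1=O` likewise returns a limit, > 100000 nM. Compound 3 `CCOC(=O)c1c(-c2ccccc2Cl)[nH]c2cccc(OC)c2c1=O` also returns a limit, > 100000 nM. All three values sit at the limit of > 100000 nM in this assay, at which 3 of the 3 values shown sit, so the series holds no readable number. Among the compounds with values here, the only single-point step among them, a step that the two limits leave unreadable from compound 2 to compound 3, is hidden by the two limits. Compound 4 `CCOC(=O)c1c(-c2ccc(Cl)c(Cl)c2)[nH]c2cc(OC)ccc2c1=O` differs from compound 1 by 3,4-dichlorophenyl in place of 2-methylphenyl on an aromatic carbon. Within the data shown here, no measured step bears on this change with a readable size, so the data give no ground to expect a step in either direction beyond the scatter. Compound 4 is estimated at 100000 nM, within a range from 30000 nM to 300000 nM. The expected step of a number no higher from compound 1 to compound 4 (the limit leaves the size open) is therefore taken as none beyond the scatter.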

Compound 4, solubility: 17000 nM
The estimate for compound 4 lay 5.9-fold (0.77 log units) above the measured number, outside the stated range (below it).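

In this assay, the aryl group on the aromatic carbon next to the ring nitrogen now has a visible effect: 3,4-dichlorophenyl in place of 2-methylphenyl gives an at least 5.8-fold lower number from compound 1 to compound 4 (0.76 log units; beyond the scatter). Within the data shown here, compound 4 therefore gives the series its first readable number, which the earlier compounds could not provide. Compound 1 remains only a limit, so the full size of the step stays unknown: the limit of > 100000 nM in this assay, at which 3 of the 4 values shown sit.

The compounds shown do not separate the loss of 2-methyl from the gain of either chlorine. Going by these compounds, how an amine or carboxylic acid on that aryl ring would read in this assay also remains open.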